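Adding a phenyl ring to the benzyl group of compound 3

The source may hold more compounds than are shown below. What is called first, only, known or untested is meant among the compounds shown, and "the series" means these compounds.

Three compounds share one core. In a functional assay on A2780 cells (Homo sapiens) for inhibition, read by MTT assay, with a stated time of 72 h (on this read-out lower numbers stand for stronger inhibition of growth and higher numbers for weaker inhibition of growth), compound 1 `O=S(=O)(NCCCNCc1ccccc1Cl)c1cc(C(F)(F)F)cc(C(F)(F)F)c1` gives 9300 nM, compound 2 `CN(CCCNS(=O)(=O)c1cc(C(F)(F)F)cc(C(F)(F)F)c1)Cc1ccccc1` gives 28000 nM, and compound 3 `O=S(=O)(NCCCNCc1ccccc1)c1cc(C(F)(F)F)cc(C(F)(F)F)c1` gives 4900 nM. Compound 3 has the lowest number of the three, though its gap to compound 1 lies within the scatter, while a 5.7-fold lower number from compound 2 to compound 3 (0.76 log units; beyond the scatter) lies beyond it. Compound 4 `O=S(=O)(NCCCNCc1ccc(-c2ccccc2)cc1)c1cc(C(F)(F)F)cc(C(F)(F)F)c1` differs from compound 3 by phenyl in place of hydrogen on an aromatic carbon. Going by the values given here, the one measured step on that same aromatic ring, a 1.9-fold lower number from compound 1 to compound 3 (0.28 log units; within the scatter), was small, and nothing here shows what a larger group does there. The change is therefore expected to give only a modest step in this assay, a 1.4-fold lower number from compound 3 to compound 4 (0.15 log units; within the scatter). Compound 4 is estimated at 3500 nM, between 900 nM and 14000 nM.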

Compound 4, concentration for 50% growth inhibition: 2600 nM
Compound 4: the middle estimate sits 1.3-fold (0.13 log units) above what was measured; measured number inside the range.
By their numbers in this assay, from the lowest: compounds 4, 3 and 1 (each within the scatter of the next, the first and the last beyond it); then compound 2.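

A phenyl ring, with its 6 heavy atoms, can replace hydrogen on this aromatic carbon, para to a large group, with only a 1.9-fold lower number from compound 3 to compound 4 (0.28 log units; within the scatter) in this assay. This step lies within the scatter, so the added ring shows neither a gain nor a loss in growth inhibition, which the small chloro step could not show for a group this large. Nothing measured here explains this tolerance.

Going by these compounds, whether a methoxy group or a pyridine ring would be tolerated on this carbon remains open. So does the effect of this phenyl ring when a methyl group sits on the amine nitrogen.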